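Sulfonyl substituent change in a short PAK4 series

The source may hold more compounds than are shown below. What is called first, only, known or untested is meant among the compounds shown, and "the series" means these compounds.

Measured compounds:
compound 1, `COc1ccc(S(N)(=O)=O)cc1C(=O)Nc1cccc(-c2nncn2C(C)C)n1`, in an assay for inhibition of serine/threonine-protein kinase PAK 4 (Homo sapiens), tested at 1 uM (on this read-out lower numbers stand for less inhibition and higher numbers for more inhibition at the one concentration tested (going by the name of the read-out)), compound 1 gives 8%
compound 2, `COc1cc(C)c(S(N)(=O)=O)cc1C(=O)Nc1cccc(-c2nncn2C(C)C)n1`, in this assay compound 2 gives 10%
compound 3, `COc1ccc(S(C)(=O)=O)cc1C(=O)Nc1cccc(-c2nncn2C(C)C)n1`, not yet measured

Both measured compounds sit at the weak end of the read-out. Among the measured compounds shown here, compound 1 holds one end of the two numbers, but the single measured step, a number 2 percentage points higher from compound 1 to compound 2 (within the scatter), is within the scatter, so the two compounds cannot be told apart on these data. For the measured compounds named here, that step, methyl in place of hydrogen on an aromatic carbon, is the only comparison available.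

Compound 3 differs from compound 1 as follows:
methyl in place of amino on a sulfonyl sulfur

Going by the values given here, no measured step touches the sulfonyl sulfur, so the measured step from compound 1 to compound 2 bears on this change only in a general way: it shows that a small change elsewhere left the read-out unmoved. With nothing pointing to a rise or a fall, the expectation for compound 3 is a step of about no change at the digits printed from compound 1 to compound 3 (within the scatter), none beyond the scatter. Compound 3 is therefore estimated at 8%, with a range from 0% to 25%.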

Compound 3, a percentage reported as inhibition, at one concentration (the size of the read-out at that concentration, not a potency): 6%
Estimate against measurement, compound 3: 2 percentage points above; the range from low to high includes it.
By their numbers in this assay, from the lowest: compounds 3, 1 and 2 (each within the scatter of the next).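

Among the compounds shown here, at the sulfonyl sulfur, amino and methyl cannot be told apart in this assay: the only reading at this position is a number 2 percentage points lower from compound 1 to compound 3 (within the scatter). For the compounds shown here, this is the first direct look at this position, and the exchange of sulfamoyl for methylsulfonyl, which removes the hydrogen-bond donor counted on the amino group, leaves no measurable mark on this read-out. Compound 3, at 6%, stays at the weak end with the earlier compounds, so the result shows no need for the amino group at this level of inhibition but cannot show a loss of much size from so low a start, and no independent data bear on the reason for the flat result.

Still open, on these data alone, is whether a larger group on the sulfonyl sulfur, such as dimethylamino or an ethyl chain, would lift the number clear of the scatter in this assay. The compounds shown also leave open what methylsulfonyl does when paired with the methyl on the aromatic carbon of compound 2, and whether any change to the shared core moves the series away from the weak end.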